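This account rests on a few compounds, and the source may have more. Where it says the series, first, only, none or still open, it means among the compounds named here.

Measured so far in a functional assay on SW480 cells (Homo sapiens) for cytotoxicity, read by MTT assay, with a stated time of 48 h; on this read-out higher numbers stand for weaker inhibition and lower numbers for stronger inhibition:
- compound 1 `O=c1ccoc2cc(OCc3cn(Cc4cccc(Br)c4)nn3)ccc12`: > 100000 nM, a limit of this assay
- compound 2 `O=c1ccoc2cc(OCc3cn(Cc4ccc(Cl)cc4Cl)nn3)ccc12`: > 100000 nM, likewise a limit
- compound 3 `O=c1ccoc2cc(OCc3cn(Cc4cccc(Cl)c4)nn3)ccc12`: 12900 nM

Within the data shown here, compound 3 holds the only number in the set; the other two values sit at the limit of > 100000 nM in this assay, at which 2 of the 3 values shown sit. Compound 4 `O=c1ccoc2cc(OCc3cn(Cc4ccccc4F)nn3)ccc12` differs from it by 2-fluorophenyl in place of 3-chlorophenyl on a saturated chain carbon bound to an aromatic nitrogen. Among the measured compounds shown here, two steps bear on this change: an at least 7.7-fold lower number from compound 1 to compound 3 (0.88 log units; beyond the scatter) and an at least 7.7-fold lower number from compound 2 to compound 3 (0.88 log units; beyond the scatter); both show that altering the halogen pattern on this phenyl can move the value off the limit, and only the 3-chlorophenyl gave a number. Compound 4 changes both the halogen and its position, so an expected step of a 3.5-fold higher number from compound 3 to compound 4 (0.54 log units; beyond the scatter) toward weaker inhibition is assumed. Compound 4 is therefore estimated at 45000 nM, within 10000 nM to 200000 nM.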

Compound 4, half-maximal inhibitory concentration: 11400 nM
Beside the measured number, compound 4's estimate is 3.9-fold (0.60 log units) above it, and the stated range covers the measured number.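

In this assay, 2-fluorophenyl in place of 3-chlorophenyl gives a 1.1-fold lower number from compound 3 to compound 4 (0.05 log units; within the scatter), so a measurable value at this place no longer rests on 3-chlorophenyl alone. Two further steps are an at least 8.7-fold lower number from compound 1 to compound 4 (0.94 log units; beyond the scatter) and an at least 8.7-fold lower number from compound 2 to compound 4 (0.94 log units; beyond the scatter). Both start from a limit and not from a number: the limit of > 100000 nM in this assay, at which 2 of the 4 values shown sit.

This change moves both the halogen and its place on the phenyl, so the two remain unseparated. Also open, going by these compounds, is how an amine or a carboxylic acid on this phenyl, or a longer chain in place of the benzyl link, would read.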